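The compounds below may be only part of what the source reports. "The series", "measured", "known", "first", "only" and "open" are said of these compounds alone.

Measured so far in an ADME assay on MT4 cells (Homo sapiens) for cytotoxicity, read by MTT assay; on this read-out higher numbers stand for lower toxicity in this test and lower numbers for higher toxicity in this test:
Compound 1 `Cc1ccccc1NC(=S)OCCc1ccccn1` gives > 100000 nM, which is a limit of the assay and not a number.
Compound 2 `S=C(Nc1ccccc1Cl)OCCc1ccccn1` gives > 100000 nM, again a limit of the assay rather than a number.
Compound 3 `S=C(Nc1ccc(Cl)c(Cl)c1)OCCc1ccccn1` gives 40000 nM.

Compound 3 is therefore the only one of the three with a number in this assay; the other two values are limits, as summed up in the limit of > 100000 nM in this assay, at which 2 of the 3 values shown sit. Compound 1 and compound 2 differ in one place: methyl in place of chloro on an aromatic carbon. Because both of their values are limits, the step that the two limits leave unreadable from compound 2 to compound 1 cannot be read. The difference between the core of compound 2 and the core of compound 3 is not broken down here.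

Compound 4 `Cc1ccc(NC(=S)OCCc2ccccn2)cc1Cl` has not yet been measured in this assay. It differs from compound 3 in one place: methyl in place of chloro on an aromatic carbon. Going by the values given here, this is the same kind of change as the one from compound 2 to compound 1, but the surroundings differ: in compound 3 the changed carbon is ortho to a chloro group and para to a large group, whereas in compound 2 it is ortho to a large group.

With the earlier step unreadable, the expectation for compound 4 rests mainly on compound 3 and its value 40000 nM. Compound 1 and compound 2 each sit at a limit of the assay, as summed up in the limit of > 100000 nM in this assay, at which 2 of the 3 values shown sit, and that also bears on the expectation. Compound 4 is expected to give about 60000 nM in this assay, with an estimated step of a 1.5-fold higher number from compound 3 to compound 4 (0.18 log units; within the scatter) that is a small one. The estimated range for compound 4 runs from 25000 nM to 150000 nM, so a limit rather than a number is a real possibility.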

Compound 4, half-maximal cytotoxic concentration: 59000 nM
Estimate against measurement, compound 4: 1.0-fold (0.01 log units) above; the measured number falls inside the stated range.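

In this assay, methyl in place of chloro on an aromatic carbon gives a 1.5-fold higher number from compound 3 to compound 4 (0.17 log units; within the scatter), so on the core of compound 3, where the changed carbon is ortho to a chloro group and para to a large group, this one pair shows no change beyond the usual scatter. It does not show that the change behaves the same way on another core, since the corresponding step from compound 2 to compound 1 cannot be read and the series therefore offers no second number to set beside this one. Compound 1 and compound 2 both stop at a limit of the test, which is not a number, and so they neither support nor contradict the result for the pair on the other core: the limit of > 100000 nM in this assay, at which 2 of the 4 values shown sit.

The compounds shown leave open whether other groups at the same aromatic carbon, such as a methoxy group, an amine or a nitrile, would also stay within the scatter of compound 3. They also leave open how a longer chain in the part joining the two rings would read in this assay, on either core.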